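This account rests on a few compounds, and the source may have more. Where it says the series, first, only, none or still open, it means among the compounds named here.

Among the measured compounds shown here, compound 1, `Cc1ccc(S(=O)(=O)N[C@@H](CC(=O)NC(C)(C)C)C(=O)NCCNC(=O)NCc2ccccc2)cc1`, is one of only two members of this set with a reading in an ADME assay on HepG2 cells (Homo sapiens) for cytotoxicity; a lower number here means that less compound is needed, a higher number that more compound is needed for the effect. In this assay compound 1 gives > 11000 nM, and that value is a limit of the assay rather than a number. Compound 2, `Cc1ccc(S(=O)(=O)N[C@@H](CC(=O)NC(C)(C)C)C(=O)NCCNC(=O)c2ccc(Cl)cc2)cc1`, differs from compound 1 in one place on a carbonyl carbon. In this assay compound 2 gives > 11000 nM, which is likewise a limit and not a number. For the measured compounds named here, the only measured step is a step that the two limits leave unreadable from compound 1 to compound 2, and its size cannot be read, since both values sit at the limit of > 11000 nM in this assay, at which 2 of the 2 values shown sit. Compound 3, `COc1cccc(C(=O)NCCNC(=O)[C@H](CC(=O)NC(C)(C)C)NS(=O)(=O)c2ccc(C)cc2)c1`, has not been measured in this assay. It differs from compound 1 as follows: 3-methoxyphenyl in place of benzylamino on a carbonyl carbon. Going by the values given here, the single measured step that bears on this change is unreadable, so no step of known size supports any expectation of movement. Compound 1 standing at a limit, the step that the limit leaves unreadable from compound 1 to compound 3 is expected to leave compound 3 at that limit as well. Compound 3 is therefore estimated at 20000 nM, with a range from 11000 nM to 60000 nM.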

Compound 3, half-maximal effective concentration: > 11000 nM
Compound 3 ended at the assay's limit (the forecaster's own chance of this, stated with the estimate: 85%); the middle value is on the limit's open side.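

In this assay compound 3 gives > 11000 nM, which is a limit and not a number. The steps linking compound 1, compound 2 and compound 3 therefore cannot be read: the limit of > 11000 nM in this assay, at which 3 of the 3 values shown sit. The compounds shown leave open whether benzylamino, 4-chlorophenyl and 3-methoxyphenyl on this carbonyl carbon differ at all in this read-out.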